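Trimming a sulfonamide: from compound 2 to compound 4

The compounds below may be only part of what the source reports. "The series", "measured", "known", "first", "only" and "open" are said of these compounds alone.

Three compounds sharing one core were tested in a functional assay on K562 cells (Homo sapiens) for antiproliferative activity, read by sulforhodamine B assay, with a stated time of 72 h; a higher number here means a weaker inhibitor, a lower number a stronger inhibitor. Compound 1 `Clc1ccc(C(/C=C/c2ccccc2)=N\Nc2nncc3ccccc23)cc1` gives 6.9 nM, compound 2 `Cc1cc(NS(=O)(=O)c2ccc(Nc3nncc4ccccc34)cc2)no1` gives 23 nM, and compound 3 `COc1ccc(NC(=S)NNc2nncc3ccccc23)cc1` gives 94 nM. On these numbers compound 2 sits in the middle, weaker than compound 1 and stronger than compound 3, both gaps beyond the usual scatter. Compound 4 `NS(=O)(=O)c1ccc(Nc2nncc3ccccc23)cc1` is not yet measured; it differs from compound 2 by hydrogen in place of 5-methyl-1,2-oxazol-3-yl on a sulfonamide nitrogen. Within the data shown here, no two measured compounds differ in a single place, so no measured step of this kind is available to guide the change. A modest loss of potency, somewhat beyond the scatter, is expected, the estimated step being a 2.6-fold higher number from compound 2 to compound 4 (0.42 log units; beyond the scatter). For compound 4 the expected value in this assay is 60 nM, within a range of 15 nM to 250 nM.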

Compound 4, half-maximal inhibitory concentration: 14 nM
The estimate for compound 4 lay 4.3-fold (0.63 log units) above the measured number; measured number outside the range, below it.
By their numbers in this assay, from the lowest: compound 1; then compounds 4 and 2 (each within the scatter of the next); then compound 3.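

Hydrogen in place of 5-methyl-1,2-oxazol-3-yl on a sulfonamide nitrogen gives a 1.6-fold lower number from compound 2 to compound 4 (0.22 log units; within the scatter) in this assay and shows what the earlier compounds could not. On this nitrogen, the five-membered aromatic ring is not needed to keep the number within the scatter of compound 2. Nothing here bears on why the two compounds read alike. Still open, as far as these compounds go, is whether anything else on this nitrogen would shift the number beyond the scatter. A methyl, an acetyl or a phenyl group there would test it.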